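The source may report more compounds than this note shows. Statements on the series, on what has been measured and on what is new or still open speak of the compounds shown alone.

In an assay on isolated protein with Bile acid receptor (Homo sapiens) as the target (a higher number here means that more compound is needed for the effect, a lower number that less compound is needed), compound 2 `COC(=O)/C=C/c1cccc(N(Cc2ccc(/C=C/c3ccccc3F)cc2)C(=O)C2CCCCC2)c1` gives 64 nM, the lowest of the three numbers measured. Compound 3 `COC(=O)/C=C/c1cccc(N(Cc2ccc(/C=C/c3ccccc3F)cc2)C(=O)NC(C)C)c1` gives 431 nM, and compound 1 `COC(=O)/C=C/c1cccc(N(Cc2ccc(/C=C/c3cc(C(F)(F)F)cc(C(F)(F)F)c3)cc2)C(=O)C(C)C)c1` gives 1950 nM. For the measured compounds named here, the one single-point step recorded, a 6.7-fold higher number from compound 2 to compound 3 (0.83 log units; beyond the scatter), concerns the group on the carbonyl carbon, not the benzyl ring. Compound 4 `COC(=O)/C=C/c1cccc(N(Cc2ccccc2)C(=O)C2CCCCC2)c1` differs from compound 2 as follows: hydrogen in place of 2-(2-fluorophenyl)ethenyl on an aromatic carbon. Going by the values given here, no measured step touches this part of the shared core, so no direct precedent exists; what is removed is a large group, and such removals are expected to raise the number markedly. For compound 4 an increase of a 47-fold higher number from compound 2 to compound 4 (1.67 log units; beyond the scatter) is therefore expected, giving an estimated 3000 nM with a range from 800 nM to 15000 nM.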

Compound 4, half-maximal effective concentration: > 1000 nM
Compound 4: only a limit was reported (the forecaster's own chance of this, stated with the estimate: 25%); the middle value lies beyond the limit too.
By their numbers in this assay, from the lowest: compound 2; then compound 3; then compound 1.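

In this assay, the earlier step changed only the group on the carbonyl carbon, whereas this one shows that the aromatic carbon carrying 2-(2-fluorophenyl)ethenyl is also sensitive: hydrogen in its place gives an at least 15-fold higher number from compound 2 to compound 4 (1.19 log units; beyond the scatter). The step is large, so the number for compound 2 depends on this group being present. For compound 4, the reported > 1000 nM is a limit and not a number, so the full size of the step stays unknown: the limit of > 1000 nM in this assay, at which 1 of the 4 values shown sits.

The compounds shown leave open which part of the group matters. An ethyl link in place of the ethenyl link, or a phenyl ring without the fluorine, might or might not keep the number close to that of compound 2.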